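This account rests on a few compounds, and the source may have more. Where it says the series, first, only, none or still open, it means among the compounds named here.

Measured in an ADME assay on microsomes from liver (Homo sapiens) for metabolic stability, read by LC-MS, using NADPH, with stated times of 10 min and 30 min; a higher number here means faster removal of the compound, a lower number slower removal:
- compound 1 `CC(=O)N[C@@H]1CCCc2c1cncc2N1CCc2cc(Cl)ccc2C1=O`: 4.3 mL/min/kg
- compound 2 `CC1CN(c2cccnc2)C(=O)c2ccc(Cl)cc21`: 6.6 mL/min/kg

Compound 1, at 4.3 mL/min/kg, and compound 2, at 6.6 mL/min/kg, lie within the usual scatter of each other, so the two numbers do not separate them. Compound 3 `CS(=O)(=O)N[C@@H]1CCCc2c1cncc2N1CCc2cc(Cl)ccc2C1=O` keeps the core of compound 1 and carries methylsulfonyl in place of acetyl on an amine nitrogen, which reads as acetamido to methanesulfonamido. Among the measured compounds shown here, no pair of measured compounds differs in one place, so the data give no direct measure of this change. In this assay, no step beyond the scatter is expected, and no direction can be called with confidence. The expected change is a 1.2-fold higher number from compound 1 to compound 3 (0.07 log units; within the scatter). For compound 3 the estimated clearance is 5 mL/min/kg, with an expected range of 2.5 mL/min/kg to 10 mL/min/kg.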

Compound 3, clearance: < 3.5 mL/min/kg
Compound 3: only a limit was reported; the forecaster's own chance of this, stated with the estimate: 10%; middle value at least 1.4-fold (0.15 log units) away from the limit.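

In this assay compound 3 carries only a limit, not a number: the limit of < 3.5 mL/min/kg in this assay, at which 1 of the 3 values shown sits. Methylsulfonyl in place of acetyl on the amine nitrogen gives an at least 1.2-fold lower number from compound 1 to compound 3 (0.08 log units; that floor lies within the scatter), so this is the first direct reading of a change at this position, though only its floor can be read. The reading shows no rise in clearance with acetamido to methanesulfonamido on the core of compound 1, while the true size of the step and any real gain beyond the scatter stay hidden behind the limit.

Going by these compounds, whether a free amine, a urea or a longer chain such as ethylsulfonyl on this nitrogen would keep clearance as low remains open. With a single pair on this core, the step also says nothing yet about how the same change behaves on other cores.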